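Replacing the thioamide chain of compound 3 with a carboxyethyl group

This account rests on a few compounds, and the source may have more. Where it says the series, first, only, none or still open, it means among the compounds named here.

Of the compounds shown here, three have been measured in a functional assay on the whole organism (stomach) for inhibition, with Rattus norvegicus as the target, at a dose of 100 mg/kg by the intraduodenal route; on this read-out lower numbers stand for less inhibition and higher numbers for more inhibition at the one dose given (going by the name of the read-out). Compound 1 `N=C(S)CCN1N=C(c2ccc(Cl)c(Cl)c2)CCC1=O` gives 47.2%, compound 2 `CC(CC(=N)S)n1ncccc1=O` gives 38.8%, and compound 3 `CC(CC(=N)S)n1nc(-c2ccccc2)ccc1=O` gives 15.5%. Compound 3 therefore stands lowest of the three: compound 2 is nearest, and the step of a number 23.3 percentage points lower from compound 2 to compound 3 (beyond the scatter) is beyond the scatter, while compound 1 is furthest and also beyond the scatter from compound 3.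

The unmeasured compound 4 `O=C(O)CCn1nc(-c2ccccc2)ccc1=O` differs from compound 3 in one place: a group of 5 heavy atoms (3 carbon, 2 oxygen; no ring) in place of a group of 6 heavy atoms (4 carbon, 1 nitrogen, 1 sulfur; no ring), on an aromatic nitrogen. Among the compounds with values here, the only measured step concerns a different site, a phenyl in place of hydrogen on an aromatic carbon, and so no measured step bears on the exchange of the chain on the aromatic nitrogen. The numbers give no guidance on whether a carboxyethyl chain in place of the chain bearing nitrogen and sulfur raises or lowers inhibition.

In that absence, the expected step of a number 1.5 percentage points higher from compound 3 to compound 4 (within the scatter) is set near zero, with a wide range on either side, since there is nothing in the measured compounds to anchor it. Compound 4 is accordingly estimated at 17%, with a range from 0% to 40%.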

Compound 4, a percentage reported as inhibition, in the whole organism at one dose (the size of the read-out at that dose, not a potency): 26.1%
The estimate for compound 4 lay 9.1 percentage points below the measured number; the measured number falls inside the stated range.
By their numbers in this assay, from the lowest: compound 3; then compound 4; then compounds 2 and 1 (each within the scatter of the next).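

In this assay, within the data shown here, the chain on the aromatic nitrogen proves to be a place where a change shows up in the number: putting 2-carboxyethyl there gives a number 10.6 percentage points higher from compound 3 to compound 4 (beyond the scatter), a modest step and the first measured at this position, as the only earlier step concerned an aromatic carbon. The chain bearing nitrogen and sulfur is therefore not required for inhibition at this dose on this phenyl-bearing core, as compound 4 lacks that chain and still gives 26.1%. No measurement at hand accounts for the rise in the number, so the step stands as an observation only.

The exchange replaces the whole chain at once, so these compounds cannot separate the effect of the group at its end from that of the rest of the chain, and they do not show whether the same exchange would give a similar step on the core of compound 2, which has hydrogen in place of phenyl. Also open, going by these compounds, is how a longer chain ending in a carboxylic acid, or a chain ending in an amine, would compare with 2-carboxyethyl at this position.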